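The compounds below may be only part of what the source reports. "The series", "measured", "known", "first", "only" and "open" are said of these compounds alone.

Compound 1 `N#CC1=C(N)Oc2c(c3nc4ccccc4nc3c3ccccc23)C12C(=O)N(Cc1cnnn1-c1cc(Cl)ccc1Cl)c1ccccc12` in an ADME assay on HUVEC cells (Homo sapiens) for antiproliferative activity, read by MTT assay, with a stated time of 48 h (on this read-out lower numbers stand for stronger inhibition and higher numbers for weaker inhibition), gives only a limit, > 50000 nM.
Compound 2 `N#CC1=C(N)Oc2c(N)cc3nc4ccccc4nc3c2C12C(=O)N(Cc1cnnn1-c1ccc(F)cc1)c1ccccc12` in this assay gives only a limit, > 50000 nM.
Compound 3 `CCOc1ccc(-n2nncc2CN2C(=O)C3(C(C#N)=C(N)Oc4c(N)cc5nc6ccccc6nc5c43)c3ccccc32)cc1` in this assay gives only a limit, > 50000 nM.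

Compound 3 stands at the limit of the read-out, where every value shown sits (the limit of > 50000 nM in this assay, at which 3 of the 3 values shown sit). For the measured compounds named here, the one step between compounds that differ in one place, a step that the two limits leave unreadable from compound 2 to compound 3, is itself unreadable, both ends being limits. Compound 4 `Cc1ccc(Cl)cc1-n1nncc1CN1C(=O)C2(C(C#N)=C(N)Oc3c(N)cc4nc5ccccc5nc4c32)c2ccccc21` differs from compound 3 as follows: 5-chloro-2-methylphenyl in place of 4-ethoxyphenyl on an aromatic nitrogen. Going by the values given here, no measured step gives a readable size or direction; the only bearing is that all three values rest at the limit (the limit of > 50000 nM in this assay, at which 3 of the 3 values shown sit). Compound 4 is therefore expected to stay near the limit too, an expected step of a number no higher from compound 3 to compound 4 (the limit leaves the size open). The estimate for compound 4 in this assay is 50000 nM, from 20000 nM to 120000 nM.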

Compound 4, half-maximal inhibitory concentration: > 50000 nM
Compound 4 gave a limit, no number; the forecaster's own chance of this, stated with the estimate: 80%; the middle value sits exactly at the limit.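

With compound 4 also at a limit, the steps to it from compound 2 and compound 3 cannot be read: the limit of > 50000 nM in this assay, at which 4 of the 4 values shown sit.

The compounds shown leave open whether any group on the aromatic nitrogen gives a measurable number in this assay.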